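The source may report more compounds than this note shows. Statements on the series, on what has been measured and on what is new or still open speak of the compounds shown alone.

In a functional assay on BXPC-3 cells (Homo sapiens) for inhibition, read by MTT assay, with a stated time of 7 days (on this read-out higher numbers stand for weaker inhibition and lower numbers for stronger inhibition), compound 3 `CCN(CC)S(=O)(=O)c1ccc(S(=O)(=O)N2CCC[C@@H](C(=O)NC3CCOCC3)C2)cc1` gives 8570 nM, the highest number of the three measured compounds. Compound 1 `CCN(CC)S(=O)(=O)c1ccc(S(=O)(=O)N2CCC[C@@H](C(=O)N[C@H]3CC[C@H](OC)CC3)C2)cc1` gives 2000 nM, and compound 2 `CCN(CC)S(=O)(=O)c1ccc(S(=O)(=O)N2CCC[C@@H](C(=O)N3CCC(OC)CC3)C2)cc1` gives 1420 nM. Compound 4 `CCN(CC)S(=O)(=O)c1ccc(S(=O)(=O)N2CCC[C@@H](C(=O)N3CCC(COC)CC3)C2)cc1` differs from compound 3 by 4-(methoxymethyl)piperidin-1-yl in place of (oxan-4-yl)amino on a carbonyl carbon. The measured step bearing most directly on this change is a 6.0-fold higher number from compound 2 to compound 3 (0.78 log units; beyond the scatter), which runs in the opposite direction, from a 4-methoxypiperidin-1-yl amide to the (oxan-4-yl)amino amide; the comparison a 1.4-fold lower number from compound 1 to compound 2 (0.15 log units; within the scatter) adds that the two methoxy-bearing six-membered variants sit together. Reversing the larger of these steps, compound 4 is expected to show a modest improvement, a 4.5-fold lower number from compound 3 to compound 4 (0.65 log units; beyond the scatter). Compound 4 is accordingly estimated at 1900 nM, within a range from 700 nM to 5500 nM.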

Compound 4, half-maximal inhibitory concentration: 1360 nM
Beside the measured number, compound 4's estimate is 1.4-fold (0.15 log units) above it; the measured number falls inside the stated range.
By their numbers in this assay, from the lowest: compounds 4, 2 and 1 (each within the scatter of the next); then compound 3.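

In this assay, 4-(methoxymethyl)piperidin-1-yl in place of (oxan-4-yl)amino on a carbonyl carbon gives a 6.3-fold lower number from compound 3 to compound 4 (0.80 log units; beyond the scatter), yet methoxymethyl in place of methoxy on a saturated ring carbon gives only a 1.0-fold lower number from compound 2 to compound 4 (0.02 log units; within the scatter), within the scatter. With a 1.5-fold lower number from compound 1 to compound 4 (0.17 log units; within the scatter) also within the scatter, compound 4 joins compound 1 and compound 2, leaving compound 3 alone at the high end. Compound 1 keeps the amide hydrogen that compound 4 lacks, so that hydrogen does not separate these compounds.

Going by these compounds, whether an amine or a carboxylic acid in place of methoxymethyl on that ring carbon would stay level with compound 4 remains open. Nothing given here explains why compound 3 stands apart.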